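From pyrimidin-5-yl to 5-methoxypyridin-3-yl on a shared core

The source may report more compounds than this note shows. Statements on the series, on what has been measured and on what is new or still open speak of the compounds shown alone.

Of the compounds shown here, three have been measured so far in an ADME assay on a cell-free system (plasma, Homo sapiens) (on this read-out lower numbers stand for a smaller free fraction and higher numbers for a larger free fraction), on the same core. Compound 1 (`CCNC(=O)Nc1nc2cc(-c3cccnc3)c(=O)n(CC3CCOCC3)c2s1`) gives 0.14 in this read-out, compound 2 (`CCNC(=O)Nc1nc2cc(-c3cccnc3)c(=O)n(C(C)C(N)=O)c2s1`) gives 0.25 in this read-out, and compound 3 (`CCNC(=O)Nc1nc2cc(-c3cncnc3)c(=O)n(C(C)C)c2s1`) gives 0.15 in this read-out. All three numbers lie within the scatter of one another, so compound 3 stands level with both others and no order can be read among them.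

The next structure is compound 4 (`CCNC(=O)Nc1nc2cc(-c3cncc(OC)c3)c(=O)n(C(C)C)c2s1`), which keeps the isopropyl group of compound 3. The change is 5-methoxypyridin-3-yl in place of pyrimidin-5-yl on an aromatic carbon on an aromatic carbon, two atoms from the ring nitrogen.

Among the measured compounds shown here, the only measured step that differs in one place is a 1.8-fold higher number from compound 1 to compound 2 (0.25 log units; within the scatter) and it stays within the scatter. That step concerns the group on the aromatic nitrogen, so it bears on the new change only indirectly. For the measured compounds named here, no measured step covers the aromatic carbon in question. No step beyond the scatter is therefore expected in this assay and only a tentative lean towards a smaller free fraction is assumed. The expected change is a 1.3-fold lower number from compound 3 to compound 4 (0.10 log units; within the scatter) and it is expected to stay within the scatter. For compound 4 the estimated value is 0.12 with an expected range from 0.06 to 0.22 in this read-out.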

Compound 4, unbound fraction in the plasma assay: 0.08
Compound 4: the middle estimate sits 1.5-fold (0.18 log units) above what was measured, and the stated range covers the measured number.
By their numbers in the plasma assay, from the lowest: compounds 4, 1, 3 and 2 (each within the scatter of the next, the first and the last beyond it).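

In the plasma assay, a 1.9-fold lower number from compound 3 to compound 4 (0.27 log units; within the scatter). Among the compounds shown here, this is the first step at this aromatic carbon, as the earlier step concerned only the group on the aromatic nitrogen, and with the isopropyl group kept, it gives no readable change in free fraction on going from pyrimidin-5-yl to 5-methoxypyridin-3-yl. In a physicochemical assay for solubility, in phosphate buffer, at pH 7.4 (on this read-out lower numbers stand for lower solubility and higher numbers for higher solubility), the same change gives an at least 1.4-fold lower number from compound 3 to compound 4 (0.14 log units; that floor lies within the scatter). In the physicochemical assay, compound 3 gives 7000 nM. In the physicochemical assay, compound 4 gives < 5000 nM, which is a limit of the assay and not a number: the limit of < 5000 nM in the physicochemical assay, at which 1 of the 2 values shown sits.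

The change swaps one ring nitrogen for a carbon and adds a methoxy group in one step, so the compounds shown cannot separate these two parts, and it remains open whether a carboxylic acid or an amine on the ring at this carbon would give a step beyond the scatter in the plasma assay. Also open, going by these compounds, is whether the step at this carbon would read the same with (oxan-4-yl)methyl or 1-carbamoylethyl in place of the isopropyl group on the aromatic nitrogen.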